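This account rests on a few compounds, and the source may have more. Where it says the series, first, only, none or still open, it means among the compounds named here.

In an ADME assay on THP-1 cells (Homo sapiens) for cytotoxicity, read by flow cytometry and propidium iodide staining, with a stated time of 72 h (on this read-out higher numbers stand for weaker inhibition and lower numbers for stronger inhibition), compound 2 (`COc1c(-c2ccccc2)oc2ccc(N)cc2c1=O`) gives 74000 nM and stands within the scatter of compound 3 (`COc1ccccc1-c1oc2ccc(N)cc2c(=O)c1OC`), which gives 116000 nM in the same read-out. Compound 1 (`Nc1ccc2oc(-c3cccc(F)c3)c(O)c(=O)c2c1`) gives 30000 nM as a lower number, beyond the scatter of compound 2.

Compound 4 (`COc1c(-c2cccc(F)c2)oc2ccc(N)cc2c1=O`) comes from compound 2 by fluoro in place of hydrogen on an aromatic carbon as fluoro in place of hydrogen on an aromatic carbon, phenyl to 3-fluorophenyl. Within the data shown here, the one measured step that adds a group to this ring is a 1.6-fold higher number from compound 2 to compound 3 (0.20 log units; within the scatter) for methoxy in place of hydrogen on an aromatic carbon. Among the measured compounds shown here, compound 1 carries the same 3-fluorophenyl group, but it has hydroxy where compound 4 has methoxy, so no measured step isolates the fluoro.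

In this assay no step beyond the scatter is expected, with only a slight lean toward compound 1 at 30000 nM in the estimate. The estimate means a 1.1-fold lower number from compound 2 to compound 4 (0.06 log units; within the scatter) as an expected step. For compound 4 the expected value is 65000 nM within an estimated range of 32000 nM to 120000 nM for the measurement.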

Compound 4, half-maximal inhibitory concentration: 34000 nM
For compound 4 the middle estimate is 1.9-fold (0.28 log units) above the measured one, and the stated range covers the measured number.
By their numbers in this assay, from the lowest: compounds 1 and 4 (each within the scatter of the next); then compounds 2 and 3 (each within the scatter of the next).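

In this assay, among these compounds, the change from phenyl to 3-fluorophenyl gives a 2.2-fold lower number from compound 2 to compound 4 (0.34 log units; beyond the scatter) for a single fluoro in place of hydrogen on an aromatic carbon, the first single change on this ring printed as beyond the scatter, while the methoxy change gives a 1.6-fold higher number from compound 2 to compound 3 (0.20 log units; within the scatter) and stays within it. With 3-fluorophenyl in place, a 1.1-fold higher number from compound 1 to compound 4 (0.05 log units; within the scatter) for methyl in place of hydrogen on the oxygen, so hydroxy and methoxy are not separated in this pair.

As far as these compounds go, whether fluoro gives a similar step on a hydroxy-bearing parent remains open. Also open, from the compounds shown here alone, is whether a chloro, a nitrile or a trifluoromethyl in the same place would follow fluoro or the methoxy change. Nothing available here gives a cause for the fluoro step.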